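Carboxy to Methylsulfonyl at the Chain Aryl Terminus

The source may hold more compounds than are shown below. What is called first, only, known or untested is meant among the compounds shown, and "the series" means these compounds.

Measured so far:
Compound 1 `O=C(O)c1cccc(CCCCCCC(=O)c2ncc(-c3ccccn3)o2)c1` — > 600 nM
Compound 2 `O=C(O)c1ccc(CCCCCCC(=O)c2ncc(-c3ccccn3)o2)cc1` — > 600 nM
Compound 3 `O=C(CCCCCCc1ccc(Cl)cc1)c1ncc(-c2ccccn2)o1` — 2.7 nM

In an assay for inhibition of Fatty-acid amide hydrolase 1 (Rattus norvegicus) (a lower number here means a stronger inhibitor, a higher number a weaker inhibitor), compound 1 gives > 600 nM, which is a limit of the assay and not a number. Compound 2 also sits at a limit, as noted in the limit of > 600 nM in this assay, at which 2 of the 3 values shown sit. Compound 3, with chloro in place of carboxy, gives 2.7 nM; the step of an at least 220-fold lower number from compound 2 to compound 3 (2.34 log units; beyond the scatter) is large. The step of an at least 220-fold lower number from compound 1 to compound 3 (2.34 log units; beyond the scatter) is equally large, whereas a step that the two limits leave unreadable from compound 1 to compound 2 cannot be read.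

Compound 4 `CS(=O)(=O)c1cccc(CCCCCCC(=O)c2ncc(-c3ccccn3)o2)c1` carries methylsulfonyl in place of carboxy on an aromatic carbon. The change removes the carboxy whose presence marks both limited compounds, but does not install chloro, so a step smaller than an at least 220-fold lower number from compound 1 to compound 3 (2.34 log units; beyond the scatter) is expected. Compound 4 is expected at 100 nM, range 10 nM to 1000 nM, meaning an expected step of an at least 6.0-fold lower number from compound 1 to compound 4 (0.77 log units; beyond the scatter).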

Compound 4, inhibition constant: 1.3 nM
Estimate against measurement, compound 4: 77-fold (1.89 log units) above; the whole stated range lies above it.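

On an aromatic carbon meta to a large group, methylsulfonyl in place of carboxy gives an at least 460-fold lower number from compound 1 to compound 4 (2.66 log units; beyond the scatter) in this assay. The earlier step from this position also moved the substituent, whereas here the position stays and only the group changes, so this position does not by itself hold the series at the limit. The value of compound 1 is a limit and not a number: the limit of > 600 nM in this assay, at which 2 of the 4 values shown sit.

Going by these compounds, it remains open whether the loss of carboxy or the arrival of methylsulfonyl drives the step. A primary amide or a sulfonamide at this position, or a shorter chain, could help separate the two.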